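Swapping the Chain on Sulfur for a Ring

This account rests on a few compounds, and the source may have more. Where it says the series, first, only, none or still open, it means among the compounds named here.

Compound 1 `Cc1cc(-c2ccc(Cl)cc2)c(S(C)(=O)=O)cc1C(=O)N=C(N)N` gives 45 nM in a functional assay for inhibition of sodium/hydrogen exchanger (Oryctolagus cuniculus); a lower number here means a stronger inhibitor, a higher number a weaker inhibitor.
Compound 2 `Cc1cc(-c2ccc(F)cc2)c(S(C)(=O)=O)cc1C(=O)N=C(N)N` gives 36 nM in this assay.
Compound 3 `Cc1cc(SC(C)C)c(S(C)(=O)=O)cc1C(=O)N=C(N)N` gives 12 nM in this assay.

Compound 3 holds the lowest number of the three: a 3.8-fold lower number from compound 1 to compound 3 (0.57 log units; beyond the scatter) and a 3.0-fold lower number from compound 2 to compound 3 (0.48 log units; beyond the scatter) are both modest steps beyond the scatter, whereas a 1.3-fold lower number from compound 1 to compound 2 (0.10 log units; within the scatter) lies within it. Compound 4 `Cc1cc(Sc2ccccc2)c(S(C)(=O)=O)cc1C(=O)N=C(N)N` is not yet measured; it differs from compound 3 by phenyl in place of isopropyl on a sulfur. For the measured compounds named here, no measured step alters the group on the sulfur itself. Because a 3.8-fold lower number from compound 1 to compound 3 (0.57 log units; beyond the scatter) and a 3.0-fold lower number from compound 2 to compound 3 (0.48 log units; beyond the scatter) show the number falling when an aryl ring gave way to isopropylsulfanyl, and compound 4 brings a ring back, a modest rise is expected, a 2.1-fold higher number from compound 3 to compound 4 (0.32 log units; beyond the scatter). Compound 4 is therefore estimated at 25 nM, within a range from 8 nM to 80 nM.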

Compound 4, half-maximal inhibitory concentration: 14 nM
Compound 4: the middle estimate sits 1.8-fold (0.25 log units) above what was measured, within the range that was stated.
By their numbers in this assay, from the lowest: compounds 3 and 4 (each within the scatter of the next); then compounds 2 and 1 (each within the scatter of the next).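

On the sulfur, phenyl serves as well as isopropyl in this assay, with a 1.2-fold higher number from compound 3 to compound 4 (0.07 log units; within the scatter). The ring itself therefore does not bring back the higher numbers: phenylsulfanyl in place of 4-fluorophenyl gives a 2.6-fold lower number from compound 2 to compound 4 (0.41 log units; beyond the scatter), and in place of 4-chlorophenyl gives a 3.2-fold lower number from compound 1 to compound 4 (0.51 log units; beyond the scatter). Among these compounds, both groups on sulfur give lower numbers than the rings without sulfur, and no available evidence explains this.

Going by these compounds, whether a longer chain, an amine or a carboxylic acid on the sulfur would fit as well remains open.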